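Loss of 4-fluorophenyl on the ring nitrogen: two pairs

This account rests on a few compounds, and the source may have more. Where it says the series, first, only, none or still open, it means among the compounds named here.

Measured so far in a functional assay on A-375 cells (Homo sapiens) for antiproliferative activity, read by MTT assay, with a stated time of 72 h; a higher number here means a weaker inhibitor, a lower number a stronger inhibitor:
compound 1, `COc1ncc(-c2ccc3c(c2)NC(=O)CO3)cc1NS(=O)(=O)c1ccc(F)cc1`: 26300 nM
compound 2, `COc1ncc(-c2ccc3c(c2)N(c2ccc(F)cc2)C(=O)CO3)cc1NS(=O)(=O)c1ccc(F)cc1`: > 40000 nM, a limit of the assay
compound 3, `O=C1COc2ccc(-c3cnc4ccccc4c3)cc2N1c1ccc(F)cc1`: > 40000 nM, a limit of the assay

Compound 2 returns only a limit of the assay in this assay, not a number. Compound 3 likewise returns only a limit. Of the three values shown, this is the limit of > 40000 nM in this assay, at which 2 of the 3 values shown sit. The difference between the core of compound 2 and the core of compound 3 is not broken down here.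

Within the first pair, the change from compound 2 to compound 1 is hydrogen in place of 4-fluorophenyl on an amide-type nitrogen in a ring. In this assay it gave an at least 1.5-fold lower number from compound 2 to compound 1 (0.18 log units; that floor lies within the scatter); since compound 2 is a limit, only a floor of the step is known.

Compound 4, `O=C1COc2ccc(-c3cnc4ccccc4c3)cc2N1`, is not yet measured in this assay. It stands to compound 3 exactly as compound 1 stands to compound 2: hydrogen in place of 4-fluorophenyl on an amide-type nitrogen in a ring. The place is the same word for word, so this is the same change, made for the second time among the compounds shown.

Compound 4 is expected to show an at least 1.3-fold lower number from compound 3 to compound 4 (0.12 log units; that floor lies within the scatter). That expectation rests on an at least 1.5-fold lower number from compound 2 to compound 1 (0.18 log units; that floor lies within the scatter), a single pair whose starting point is itself a limit, and on compound 3 being known only as a limit, so the step cannot be sized tightly. Compound 4 is estimated at 30000 nM, between 12000 nM and 80000 nM, with a real chance that only a limit is returned.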

Compound 4, half-maximal inhibitory concentration: > 40000 nM
Compound 4 was reported as a limit (the forecaster's own chance of this, stated with the estimate: 45%); middle value at least 1.3-fold (0.12 log units) from the limit.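

In this assay, compound 3 and compound 4 each return only a limit of the assay, so no step between them can be read: the limit of > 40000 nM in this assay, at which 3 of the 4 values shown sit.

The compounds shown leave open whether hydrogen in place of 4-fluorophenyl on an amide-type nitrogen in a ring changes the activity at all, as neither pair has a measured number at both ends.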